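Swapping one fluoro for trifluoromethyl in a weak compound

A few compounds are considered here, and "the series" means these few. Any claim that something is new, unique, unknown or untested is made for them only; others in the source may bear on it.

Measured so far in a functional assay on HT-29 cells (Homo sapiens); a lower number here means a stronger inhibitor of growth, a higher number a weaker inhibitor of growth
- compound 1 `O=S(=O)(/C=C/c1ccc(F)cc1)Cc1ccc(Nc2ncnc3ccccc23)cc1` gives 1000 nM
- compound 2 `O=S(=O)(/C=C/c1ccc(F)cc1F)Cc1ccc(Nc2ncnc3ccccc23)cc1` gives > 100000 nM (a limit of the assay, not a number)

Compound 2 stands at the limit of > 100000 nM in this assay, at which 1 of the 2 values shown sits. It therefore has no exact value, and any true figure lies beyond what this assay reports.

Compound 3 `O=S(=O)(/C=C/c1ccc(C(F)(F)F)cc1F)Cc1ccc(Nc2ncnc3ccccc23)cc1` keeps the shared core and changes one group: trifluoromethyl in place of fluoro on an aromatic carbon. Trifluoromethyl takes the place of fluoro on an aromatic carbon, turning 2,4-difluorophenyl into 2-fluoro-4-(trifluoromethyl)phenyl.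

For the measured compounds named here, only one measured step is available, and it is large: an at least 100-fold higher number from compound 1 to compound 2 (2.00 log units; beyond the scatter). That step added a fluoro which compound 3 retains, while the fluoro now leaving is present in both compound 1 and compound 2. Going by the values given here, no measured step covers the new change itself, so it offers only indirect guidance. Compound 3 is expected to remain a weak inhibitor of growth, with a modest move towards a lower number at best, and it may also reach the limit. The expected change is an at least 3.3-fold lower number from compound 2 to compound 3 (0.52 log units; beyond the scatter). For compound 3 the estimated value is 30000 nM, with an expected range from 3000 nM to 100000 nM.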

Compound 3, concentration for 50% growth inhibition: 100000 nM
For compound 3 the middle estimate is 3.3-fold (0.52 log units) below the measured one; measured number inside the range.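

In this assay compound 3 gives 100000 nM, a reading that is an exact number, so this ring change can be sized against compound 1. Replacing 4-fluorophenyl with 2-fluoro-4-(trifluoromethyl)phenyl gives a 100-fold higher number from compound 1 to compound 3 (2.00 log units; beyond the scatter), which shows that growth inhibition stays poor with trifluoromethyl in the place of the fluoro, and that this larger group brings no recovery of the strength seen in compound 1. The direct swap of fluoro for trifluoromethyl gives a number no higher from compound 2 to compound 3 (the limit leaves the size open). This swap still has no readable size, because compound 2 has only a limit and no exact value: the limit of > 100000 nM in this assay, at which 1 of the 3 values shown sits.

The compounds shown leave open whether the 2-fluoro group alone accounts for the weak growth inhibition of compound 2 and compound 3, or whether the group at the other ring position also contributes. Also open, on these data alone, is how this assay would read with an amine or a methoxy group on that same aromatic carbon, which would show whether any group there can restore growth inhibition while the 2-fluoro group stays in place.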